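Thiophene series: thioester to cyclohexyl ester at the carbonyl

The compounds below may be only part of what the source reports. "The series", "measured", "known", "first", "only" and "open" are said of these compounds alone.

Compound 2 `CCSC(=O)C1=C(C)NC(=O)NC1c1ccsc1` gives 17% in an assay on membranes from HEK293 cells for displacement of a labelled ligand from adenosine receptor A2b (Homo sapiens), read by scintillation counting, with a stated time of 30 min, tested at 1 uM (on this read-out higher numbers stand for more inhibition at the one concentration tested (going by the name of the read-out) and lower numbers for less inhibition), and holds the higher of the two measured numbers, while compound 1 `CCSC(=O)C1=C(C)NC(=O)NC1c1ccoc1` gives 1% in this assay. For the measured compounds named here, the one measured step, a number 16 percentage points higher from compound 1 to compound 2 (beyond the scatter), turns on the aryl group at the saturated ring carbon and leaves the carbonyl substituent untouched.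

Compound 3 `CC1=C(C(=O)OC2CCCCC2)C(c2ccsc2)NC(=O)N1` differs from compound 2 only at the carbonyl carbon: cyclohexyloxy in place of ethylsulfanyl on a carbonyl carbon. Going by the values given here, no measured pair varies the group on that carbonyl carbon, so the step of a number 16 percentage points higher from compound 1 to compound 2 (beyond the scatter) does not bear on this change, and its modest size says nothing about how the read-out answers a swap at the carbonyl. With no anchor for a direction, the expectation is for no step beyond the scatter, the estimated step being a number 2 percentage points lower from compound 2 to compound 3 (within the scatter). For compound 3 the expected value in this assay is 15%, with a range from 0% to 40% set wide. The data hold no comparison at the carbonyl to narrow it.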

Compound 3, a percentage reported as inhibition, at one concentration (the size of the read-out at that concentration, not a potency): 4%
Beside the measured number, compound 3's estimate is 11 percentage points above it; measured number inside the range.
By their numbers in this assay, from the lowest: compounds 1 and 3 (each within the scatter of the next); then compound 2.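

The carbonyl position now has its first measured step: in this assay, cyclohexyloxy in place of ethylsulfanyl on a carbonyl carbon gives a number 13 percentage points lower from compound 2 to compound 3 (beyond the scatter). The read-out therefore does respond to a change at this carbonyl carbon, which the earlier aryl step could not show, and with the thiophen-3-yl group held constant, the ethylsulfanyl compound carries the higher number. The data offer nothing that explains this step.

The change replaces the atom attached to the carbonyl carbon and the group beyond it in a single move, sulfur with oxygen and a two-carbon chain with a six-membered ring, so the step cannot be assigned to either part; an ethoxy group or a cyclohexylsulfanyl group at the same carbon would separate the two. Also open, going by these compounds, are whether the step carries over to the furan-3-yl compounds and how the read-out responds to an amide or a carboxylic acid at this carbonyl carbon.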